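The source may hold more compounds than are shown below. What is called first, only, known or untested is meant among the compounds shown, and "the series" means these compounds.

Measured in a functional assay on KB cells (Homo sapiens) for inhibition; a lower number here means a stronger inhibitor, a higher number a weaker inhibitor:
compound 1, `CCOC(c1ccccc1)c1ccc(C(C)C)cc(=O)c1O`: 0.3 ug/mL
compound 2, `CCOC(c1ccc(OC)cc1)c1ccc(C(C)C)cc(=O)c1O`: 0.5 ug/mL
compound 3, `CC(=O)C1=C(O)CN(C2OCCc3ccccc32)C1=O`: > 100 ug/mL

Compound 1 gives the lowest of the two numbers in this assay, 0.3 ug/mL. Its nearest neighbour is compound 2, and the step of a 1.7-fold higher number from compound 1 to compound 2 (0.22 log units; within the scatter) lies within the scatter, so the two cannot be told apart. For compound 3 the assay reports only a limit, > 100 ug/mL, and not a number; it is the limit of > 100 ug/mL in this assay, at which 1 of the 3 values shown sits.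

Compound 4, `CC(C)c1ccc(C(Sc2ccccc2)c2ccccc2)c(O)c(=O)c1`, has not been measured. It differs from compound 1 in one place: phenylsulfanyl in place of ethoxy on a saturated chain carbon bound to two aromatic carbons. None of the measured steps touches this carbon; the only step shown, from methoxy in place of hydrogen on an aromatic carbon, was within the scatter. There is therefore no measured basis for expecting a change beyond the scatter in this assay in either direction, and the expected step of a 1.7-fold higher number from compound 1 to compound 4 (0.22 log units; within the scatter) is a modest one. Compound 4 is thus estimated at 0.5 ug/mL, with a range from 0.1 ug/mL to 3 ug/mL.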

Compound 4, concentration for 50% inhibition: 0.5 ug/mL
The estimate for compound 4 equals the measured number at the digits printed, within the range that was stated.
By their numbers in this assay, from the lowest: compounds 1, 2 and 4 (each within the scatter of the next). At a limit, above all of these: compound 3.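

In this assay the replacement on the saturated chain carbon bound to two aromatic carbons gives a 1.7-fold higher number from compound 1 to compound 4 (0.22 log units; within the scatter), so compound 1 and compound 4 cannot be told apart. The earlier step touched only an aromatic carbon, whereas this one shows that the chain carbon can carry phenylsulfanyl, with 7 heavy atoms and a six-membered aromatic ring, in place of ethoxy, with 3 heavy atoms and no ring, without a difference beyond the scatter. Nothing shown gives a reason for this result.

The compounds shown leave open how an amine or a carboxylic acid on this carbon would read in this assay, and whether a group without sulfur or a ring would do the same. They also leave open whether methoxy on the ring of the phenylsulfanyl group would stay within the scatter.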